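Removing One Methyl from a Growth Inhibitor

A few compounds are considered here, and "the series" means these few. Any claim that something is new, unique, unknown or untested is made for them only; others in the source may bear on it.

Compound 1 `Cc1ccnc2nc(-c3cccc4ccccc34)cc(O)c12`: < 10 nM, a limit
Compound 2 `Cc1cc(C)c2c(O)cc(-c3cccc4ccccc34)nc2n1`: 631 nM

For the measured compounds named here, in a functional assay on NCI-H460 cells (Homo sapiens) for antiproliferative activity (a higher number here means a weaker inhibitor of growth, a lower number a stronger inhibitor of growth), compound 2 gives 631 nM, the only true number so far. Compound 1 stands at a limit: the limit of < 10 nM in this assay, at which 1 of the 2 values shown sits. Compound 3 `Cc1ccc2c(O)cc(-c3cccc4ccccc34)nc2n1` has hydrogen in place of methyl on an aromatic carbon of compound 2: hydrogen in place of methyl on an aromatic carbon. Going by the values given here, the one measured step, an at least 63-fold higher number from compound 1 to compound 2 (1.80 log units; beyond the scatter), added a methyl on a different carbon, and compound 3 keeps that methyl. That step therefore bears on this change only indirectly. A moderate move to a lower number, smaller than that step, is expected: a 4.2-fold lower number from compound 2 to compound 3 (0.62 log units; beyond the scatter). For compound 3 the estimate is 150 nM, with an expected range of 15 nM to 1000 nM.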

Compound 3, concentration for 50% growth inhibition: 17.4 nM
Estimate against measurement, compound 3: 8.6-fold (0.94 log units) above, and the stated range covers the measured number.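

In this assay, replacing the methyl on this aromatic carbon, opposite the ring nitrogen, with hydrogen gives a 36-fold lower number from compound 2 to compound 3 (1.56 log units; beyond the scatter). Together with the earlier step, an at least 63-fold higher number from compound 1 to compound 2 (1.80 log units; beyond the scatter), this shows that compound 2, which carries both methyl groups, has a much higher number than either compound with only one. Compound 1 remains a limit and not a number: the limit of < 10 nM in this assay, at which 1 of the 3 values shown sits.

The compounds shown leave open how an ethyl chain, a chlorine atom or an amine on this carbon would compare with hydrogen. From the compounds shown here alone, how the shared core would stand with hydrogen in place of both methyl groups also remains open.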